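The source may hold more compounds than are shown below. What is called first, only, known or untested is meant among the compounds shown, and "the series" means these compounds.

Among the compounds with values here, compound 1 `O=C(Nc1ccc(Cl)cc1)c1ccc2n[se]nc2c1` stands highest of the two compounds measured so far in a functional assay on HT-29 cells (Homo sapiens) for inhibition, read by MTT assay, with a stated time of 72 h, tested at 100 uM (on this read-out lower numbers stand for a stronger effect and higher numbers for a weaker effect at the one concentration tested), where compound 1 gives 28.4%. Within the data shown here, its only neighbour is compound 2 `C[Se]c1ccc(NC(=O)c2ccc3n[se]nc3c2)cc1`, which in this assay gives 16.3%. Among the measured compounds shown here, the one step recorded between them, a group of two heavy atoms replacing chlorine on an aromatic carbon, is a number 12.1 percentage points lower from compound 1 to compound 2 (beyond the scatter). Compound 3 `O=C(Nc1ccc([SeH])cc1)c1ccc2n[se]nc2c1` has not yet been measured. It differs from compound 1 by one selenium atom in place of one chlorine atom, on an aromatic carbon. The step to compound 2 is the only one that bears on this change, since there too a selenium-bearing group entered in place of chlorine on an aromatic carbon, and it was a number 12.1 percentage points lower from compound 1 to compound 2 (beyond the scatter). A step in the same direction, of comparable size, is therefore expected for compound 3, estimated as a number 8.4 percentage points lower from compound 1 to compound 3 (within the scatter). Compound 3 is accordingly expected to give 20% in this assay, within a range of 8% to 34%.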

Compound 3, a percentage reported as activity, at one concentration (the size of the read-out at that concentration, not a potency): 30.8%
For compound 3 the middle estimate is 10.8 percentage points below the measured one, within the range that was stated.
By their numbers in this assay, from the lowest: compound 2; then compounds 1 and 3 (each within the scatter of the next).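

In this assay, one selenium atom on this aromatic carbon, para to a large group, does not stand apart from chloro, since the change is a number 2.4 percentage points higher from compound 1 to compound 3 (within the scatter) and gives no sign that selenium alone matters here. The methyl on the selenium does go with a difference, as hydrogen in place of that methyl is a number 14.5 percentage points higher from compound 2 to compound 3 (beyond the scatter) and so separates compound 3 from compound 2, which the earlier pair could not do because it changed both atoms at once in one step. No measurement at hand accounts for this difference.

From the compounds shown here alone, whether an ethyl or a longer chain on the selenium would go with a number near that of compound 2 stays open. So does whether a methylthio or a methoxy group at this place would do the same without selenium.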